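The source may report more compounds than this note shows. Statements on the series, on what has been measured and on what is new or still open speak of the compounds shown alone.

Measured so far:
- compound 1 `Cc1cccc(NC(=O)CN2CCN(c3ccc(Cl)cn3)CC2)c1`: "not active" (no number reported)
- compound 2 `Cc1cccc(NC(=O)CN2CCN(c3ncccn3)CC2)c1`: 3.4 nM

Among the measured compounds shown here, in a functional assay on cells for agonist activity at D(4) dopamine receptor (Homo sapiens), read by TR-FRET and cAMP accumulation, with a stated time of 30 min (on this read-out lower numbers stand for an effect already at smaller amounts and higher numbers for an effect only at larger amounts of compound), compound 2 gives 3.4 nM, the only number obtained. For the measured compounds named here, compound 1 is reported as "not active" (no number reported) in this assay, without a number, so no step between the two can be sized. Compound 3 `Cc1cccc(NC(=O)CN2CCN(c3ccccn3)CC2)c1` has not yet been measured. It differs from compound 2 in one place: pyridin-2-yl in place of pyrimidin-2-yl on an amine nitrogen in a ring. Going by the values given here, no measured pair shows this exact change, so its effect can only be guessed. Compound 1, which also carries a pyridin-2-yl on that ring nitrogen, though one bearing a further chlorine, showed no activity, which argues against assuming compound 3 keeps the strength of compound 2. A moderate loss is therefore expected, a 4.4-fold higher number from compound 2 to compound 3 (0.64 log units; beyond the scatter), with wide uncertainty in both directions. Compound 3 is estimated at 15 nM, within a range of 3 nM to 150 nM.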

Compound 3, half-maximal effective concentration: 3.6 nM
Compound 3: the middle estimate sits 4.2-fold (0.62 log units) above what was measured; low and high end bracket the measured number.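

In this assay, putting pyridin-2-yl in place of pyrimidin-2-yl on the amine nitrogen in the ring gives a 1.1-fold higher number from compound 2 to compound 3 (0.02 log units; within the scatter), so at this position the ring with two nitrogens and the ring with one read alike. Compound 3 gives 3.6 nM, while compound 1, which differs from it only by a further chlorine on the pyridin-2-yl, is reported as "not active" (no number reported); that step cannot be sized, but the lack of a number for compound 1 cannot be blamed on the pyridin-2-yl ring alone. Nothing shown here explains why these two rings give matching results.

Still open, on these data alone, is whether any ring nitrogen is needed at all, as a plain phenyl ring at this position would show. Also open, as far as these compounds go, is how a methyl, methoxy or amine group would fare where compound 1 carries its chlorine.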